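Aryl ketone variation at the histamine H2 receptor

This account rests on a few compounds, and the source may have more. Where it says the series, first, only, none or still open, it means among the compounds named here.

Measured so far:
compound 1 `C=C(C)C(=O)c1ccc(OCCCN2CCN(C(=O)OCC)CC2)cc1` — 22400 nM
compound 2 `CCOC(=O)N1CCN(CCCOc2ccc(C(=O)c3ccc(C(C)(C)C)cc3)cc2)CC1` — 1550 nM

Both compounds share a core carrying a carbonyl, and were tested in an assay on isolated protein for binding affinity to histamine H2 receptor (Homo sapiens); a lower number here means a stronger inhibitor, a higher number a weaker inhibitor. Compound 1 gives 22400 nM, while compound 2 gives 1550 nM. Going by the values given here, the one step seen, a 14-fold lower number from compound 1 to compound 2 (1.16 log units; beyond the scatter), shows that a 4-(tert-butyl)phenyl in place of 1-methylethenyl on the carbonyl carbon brings a strong gain. Compound 2 therefore stands as the lower of the two numbers, with compound 1 well beyond the scatter above it.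

Compound 3 `CCOC(=O)N1CCN(CCCOc2ccc(C(=O)c3cccc(C)c3)cc2)CC1` keeps the aromatic ring at the carbonyl but changes it: 3-methylphenyl in place of 4-(tert-butyl)phenyl on a carbonyl carbon. The step from compound 1 to compound 2 bears on this only in part, since it shows that an aryl group at the carbonyl helps a great deal, but it does not tell how much of that gain rests on the 4-(tert-butyl) group itself. Among the compounds with values here, with only that step to go on, compound 3 is expected to stay clearly closer to compound 2 than to compound 1, yet some loss from the smaller ring substituent is expected: a 2.3-fold higher number from compound 2 to compound 3 (0.35 log units; beyond the scatter). The estimate for compound 3 in this assay is 3500 nM, with a range from 1200 nM to 10000 nM.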

Compound 3, inhibition constant: 3720 nM
Compound 3: middle estimate off by 1.1-fold (0.03 log units), on the low side, and the stated range covers the measured number.
By their numbers in this assay, from the lowest: compound 2; then compound 3; then compound 1.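

In this assay, putting 3-methylphenyl in place of 4-(tert-butyl)phenyl on the carbonyl carbon gives a 2.4-fold higher number from compound 2 to compound 3 (0.38 log units; beyond the scatter). This shows that the substituents on the ring matter at this position: two aryl ketones that are otherwise identical still differ by more than the scatter. The gain over 1-methylethenyl does not depend on the 4-(tert-butyl) group alone, as 3-methylphenyl in place of 1-methylethenyl gives a 6.0-fold lower number from compound 1 to compound 3 (0.78 log units; beyond the scatter), although compound 2 remains the lowest of the three and no measurement available here explains these differences.

The step from compound 2 to compound 3 changes both the ring substituent and where it sits, so the compounds shown cannot separate the effect of tert-butyl versus methyl from that of its place on the ring; a 4-methylphenyl or 3-(tert-butyl)phenyl group would be needed to pull the two apart. On these data alone, it also remains open how an unsubstituted phenyl ring would compare, and whether a ring carrying an amine or a carboxylic acid would be tolerated on this carbonyl carbon.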